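Replacing a Naphthyl Group on a Cyanopyridine Scaffold

The compounds below may be only part of what the source reports. "The series", "measured", "known", "first", "only" and "open" are said of these compounds alone.

Compound 1 `COc1nc(-c2cc3ccccc3o2)cc(-c2cccc3ccccc23)c1C#N` gives 359000 nM in a functional assay on aorta (strain Wistar) for inhibition, with Thoracic aorta (Rattus norvegicus) as the target; a higher number here means a weaker inhibitor, a lower number a stronger inhibitor. Compound 2 `CCOc1nc(-c2cc3ccccc3o2)cc(-c2cccc3ccccc23)c1C#N` gives 344000 nM in this assay. Compound 3 `COc1nc(-c2cc3ccccc3o2)cc(-c2ccc(C)cc2)c1C#N` gives 266000 nM in this assay.

Compound 2 stands second highest among the three numbers. Within the data shown here, its nearest neighbour is compound 1, and the single change between them, a 1.0-fold lower number from compound 1 to compound 2 (0.02 log units; within the scatter), lies within the scatter. Compound 3 lies furthest from compound 2, yet that gap, too, is within the scatter, so none of the three can be called the strongest or the weakest inhibitor.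

The step to compound 4 `CCOc1nc(-c2cc3ccccc3o2)cc(-c2ccc(OC)cc2)c1C#N` is 4-methoxyphenyl in place of naphthalen-1-yl on an aromatic carbon. Among the measured compounds shown here, no measured step matches this exchange. The closest comparison is between compound 1 and compound 3, which differ in the same position, with naphthalen-1-yl against 4-methylphenyl, and their two values sit within the scatter of each other. That pair gives no reason to expect a move beyond the scatter when 4-methoxyphenyl enters, though the methoxy group makes the analogy imperfect.

For compound 4 the expected step is a 1.2-fold lower number from compound 2 to compound 4 (0.07 log units; within the scatter), which is no real change. Compound 4 is therefore estimated at 290000 nM, within a range from 150000 nM to 550000 nM.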

Compound 4, half-maximal inhibitory concentration: 204000 nM
Compound 4: the middle estimate sits 1.4-fold (0.15 log units) above what was measured, within the range that was stated.
By their numbers in this assay, from the lowest: compounds 4, 3, 2 and 1 (each within the scatter of the next).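

In this assay, the exchange of naphthalen-1-yl for 4-methoxyphenyl, on the aromatic carbon opposite the ring nitrogen, gives a 1.7-fold lower number from compound 2 to compound 4 (0.23 log units; within the scatter), so the two compounds cannot be told apart. Among these compounds, this is the first step read directly at this position, and it shows that the number stays within the scatter even though the group entering has one six-membered aromatic ring rather than two, has fewer heavy atoms and brings a hydrogen-bond acceptor that naphthalen-1-yl lacks. No measurement at hand bears on why the position responds so little to this exchange.

The compounds shown carry only aromatic carbon rings at this position, so it remains open whether an amine or a carboxylic acid on that phenyl ring, or a small saturated ring in its place, would carry the number beyond the scatter. From the compounds shown here alone, it also remains open whether a longer chain than ethoxy on the oxygen, such as butoxy, or an amine in place of that group, would do so.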